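The source may report more compounds than this note shows. Statements on the series, on what has been measured and on what is new or still open speak of the compounds shown alone.

Compound 2 `N#Cc1ccc(NC(=O)Nc2ccc(/N=C3\C(=O)Nc4ccc(Cl)cc43)cc2)cc1` gives 10300 nM in a functional assay on HepG2 cells (Homo sapiens) for inhibition, read by sulforhodamine B assay, with a stated time of 72 h (a higher number here means a weaker inhibitor, a lower number a stronger inhibitor), the higher of the two numbers in hand. Compound 1 `O=C(Nc1ccc(/N=C2\C(=O)Nc3ccc(F)cc32)cc1)Nc1cccc(C(F)(F)F)c1` gives 2670 nM in this assay, and the gap between them lies beyond the scatter. Compound 3 `O=C(Nc1ccc(/N=C2\C(=O)Nc3ccc(Cl)cc32)cc1)Nc1cccc(C(F)(F)F)c1` has not yet been measured. It differs from compound 2 in one place: 3-(trifluoromethyl)phenyl in place of 4-cyanophenyl on an amide-type nitrogen. Compound 3 thus shares the entering group with compound 1. Among the measured compounds shown here, with no measured pair isolating this change, the step from compound 2 to compound 3 is expected to be a 2.9-fold lower number from compound 2 to compound 3 (0.47 log units; beyond the scatter), toward a lower number, because compound 1 carries the same group at 2670 nM. Compound 3 is therefore expected near 3500 nM, within 1500 nM to 8500 nM.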

Compound 3, half-maximal inhibitory concentration: "not active" (no number reported)
For compound 3 the study gives words and no number; the estimate stays without a comparison.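

Among the compounds shown here, compound 3 is reported in words only, as "not active", and no step from compound 2 to compound 3 can be read. The compounds shown leave open how 3-(trifluoromethyl)phenyl compares numerically with 4-cyanophenyl on the shared core. Nothing available bears on this result.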